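Phenyl replacing 3-chloro-4-fluorophenyl in a sulfonyl oxadiazole series

The source may report more compounds than this note shows. Statements on the series, on what has been measured and on what is new or still open speak of the compounds shown alone.

Compound 1 `CC(O)(CS(=O)(=O)c1ccccc1)c1nc(-c2ccccc2)no1` was tested in a functional assay on DU-145 cells (Homo sapiens) for cytotoxicity, read by MTT assay; on this read-out lower numbers stand for stronger inhibition and higher numbers for weaker inhibition. In this assay compound 1 reaches only a limit of > 100000 nM, not a number. Compound 2 `CC(O)(CS(=O)(=O)c1ccc(Br)cc1)c1nc(-c2ccc(F)c(Cl)c2)no1` gives 75000 nM in this assay, the only number shown. The other value, that of compound 1, is the limit of > 100000 nM in this assay, at which 1 of the 2 values shown sits. Compound 3 `CC(O)(CS(=O)(=O)c1ccc(Br)cc1)c1nc(-c2ccccc2)no1` differs from compound 2 by phenyl in place of 3-chloro-4-fluorophenyl on an aromatic carbon. Within the data shown here, no step between measured compounds is known, so the step in this assay is expected to be small, at most a drift toward weaker inhibition. The expected step of a 1.3-fold higher number from compound 2 to compound 3 (0.12 log units; within the scatter) follows that view. Compound 3 is estimated at 100000 nM, ranging from 40000 nM to 300000 nM.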

Compound 3, half-maximal inhibitory concentration: > 100000 nM
Compound 3 ended at the assay's limit; the forecaster's own chance of this, stated with the estimate: 55%; the middle value sits exactly at the limit.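

Phenyl in place of 3-chloro-4-fluorophenyl on this aromatic carbon gives an at least 1.3-fold higher number from compound 2 to compound 3 (0.12 log units; that floor lies within the scatter) in this assay, so the floor of the step shows no clear loss, while its true size remains unknown. Compound 3 gives a limit, not a number, and the series now rests largely on such limits: the limit of > 100000 nM in this assay, at which 2 of the 3 values shown sit. The step from compound 1 to compound 3 cannot be read, so bromo in place of hydrogen remains unresolved.

The compounds shown leave open whether 3-chlorophenyl, 4-fluorophenyl or an aminophenyl group at this place would give a readable number.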